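Swapping an aryl ring for a furan amide on piperazine

This account rests on a few compounds, and the source may have more. Where it says the series, first, only, none or still open, it means among the compounds named here.

Compound 1 `CN1CCN(C(=S)SC(=S)N(C)C)CC1` is a small dithiocarbamate with a methyl on the ring nitrogen; in an ADME assay on HeLa cells (Homo sapiens) for cytotoxicity, read by MTT assay, with a stated time of 24 h (on this read-out lower numbers stand for stronger inhibition and higher numbers for weaker inhibition), compound 1 gives 1220000 nM. Compound 2 `CN(C)C(=S)SC(=S)N1CCN(c2cccc(Cl)c2)CC1` carries a 3-chlorophenyl on that nitrogen instead. In this assay compound 2 reaches only a limit, > 5000000 nM, which is no number. Going an at least 4.0-fold higher number from compound 1 to compound 2 (0.61 log units; beyond the scatter), so compound 2 sits at the weak end of what has been measured, with the limit of > 5000000 nM in this assay, at which 1 of the 2 values shown sits. Compound 3 `CN(C)C(=S)SC(=S)N1CCN(C(=O)c2ccco2)CC1` differs from compound 2 as follows: (furan-2-yl)carbonyl in place of 3-chlorophenyl on an amine nitrogen in a ring. Among the compounds with values here, no measured step covers this particular exchange; the single step available replaced methyl with 3-chlorophenyl and made the number rise. Compound 3 is therefore expected to remain weakly cytotoxic, with the estimated step of an at least 1.2-fold lower number from compound 2 to compound 3 (0.09 log units; that floor lies within the scatter) lying within the scatter or modestly downward. For compound 3 the estimate is 4000000 nM, with a range from 1500000 nM to 10000000 nM.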

Compound 3, half-maximal inhibitory concentration: 2380000 nM
Estimate against measurement, compound 3: 1.7-fold (0.23 log units) above; the range from low to high includes it.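

In this assay, the ring nitrogen does not treat all aromatic groups alike: (furan-2-yl)carbonyl in place of 3-chlorophenyl gives an at least 2.1-fold lower number from compound 2 to compound 3 (0.32 log units; beyond the scatter). The two groups share a heavy-atom count and each holds one aromatic ring, but the entering group also brings a carbonyl and hydrogen-bond acceptors, and these compounds cannot say which difference matters. Set against the methyl of the first compound, the same group gives a 2.0-fold higher number from compound 1 to compound 3 (0.29 log units; within the scatter), so those two values cannot be told apart.

From the compounds shown here alone, compound 2 stands only as a limit, so the true size of the step away from it stays open: the limit of > 5000000 nM in this assay, at which 1 of the 3 values shown sits. Also open is how this nitrogen would read with a plain benzoyl, which keeps the carbonyl but changes the ring, or with a longer chain ending in a carboxylic acid.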